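A few compounds are considered here, and "the series" means these few. Any claim that something is new, unique, unknown or untested is made for them only; others in the source may bear on it.

Compound 1 `Cc1ccc(S(C)(=O)=O)cc1C#Cc1cc(Cl)ccc1OCC(=O)O`: 5 nM
Compound 2 `CS(=O)(=O)c1ccc(Cl)c(C#Cc2cc(Cl)ccc2OCC(=O)O)c1`: 3.5 nM
Compound 3 `CC(C)c1ccc(S(C)(=O)=O)cc1C#Cc1cc(Cl)ccc1OCC(=O)O`: 4.6 nM

In an assay on CHO cells for displacement of a labelled ligand from prostaglandin D2 receptor 2 (Homo sapiens), read by scintillation counting (on this read-out higher numbers stand for weaker inhibition and lower numbers for stronger inhibition), compound 1 gives 5 nM, the highest of the three numbers, yet neither step away from it goes beyond the scatter: a 1.1-fold lower number from compound 1 to compound 3 (0.04 log units; within the scatter) and a 1.4-fold lower number from compound 1 to compound 2 (0.15 log units; within the scatter). Between the other two the picture is the same, a 1.3-fold higher number from compound 2 to compound 3 (0.12 log units; within the scatter). All three measured changes replace one group on an aromatic carbon of the shared core and leave the methylsulfonyl untouched.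

Compound 4 `Cc1ccc(S(=O)(=O)N2CCOCC2)cc1C#Cc1cc(Cl)ccc1OCC(=O)O` departs from compound 1 at a different place: morpholin-4-yl in place of methyl on a sulfonyl sulfur. Among the compounds with values here, none of the measured steps alters the sulfonyl sulfur, so none bears directly on this change; the series only shows that nearby variation on the aromatic carbon moved this assay by no more than the scatter. Within the data shown here, with no direct precedent, the step from compound 1 to compound 4 is expected to be modest, a 1.8-fold higher number from compound 1 to compound 4 (0.26 log units; within the scatter), leaning toward a somewhat higher number. Compound 4 is therefore estimated at 9 nM, within 3 nM to 30 nM.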

Compound 4, inhibition constant: 3.6 nM
Compound 4: the middle estimate sits 2.5-fold (0.40 log units) above what was measured; low and high end bracket the measured number.
By their numbers in this assay, from the lowest: compounds 2, 4, 3 and 1 (each within the scatter of the next).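

Compound 4 is the only compound shown that changes the sulfonyl sulfur, and in this assay morpholin-4-yl in place of methyl there gives a 1.4-fold lower number from compound 1 to compound 4 (0.14 log units; within the scatter) despite 6 heavy atoms entering where 1 leaves. The sulfonyl sulfur thus joins the aromatic carbon as a place where a change in these compounds stays within the scatter, here with a six-membered non-aromatic ring and a hydrogen-bond acceptor brought in. Nothing measured here explains why the number holds at this place.

The compounds shown leave open how a piperidine ring, a dimethylamino group or an amine on a longer chain would read on the sulfonyl sulfur. They also leave open whether morpholin-4-yl gives the same result with chloro or isopropyl on the aromatic carbon in place of methyl.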